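A few compounds are considered here, and "the series" means these few. Any claim that something is new, unique, unknown or untested is made for them only; others in the source may bear on it.

Measured compounds:
- compound 1, `CC(C)CCSc1nc(C(F)(F)F)ccc1CNC(=O)C(C)c1ccc(NS(C)(=O)=O)c(F)c1`, gives 82 nM
- compound 2, `CC(C(=O)NCc1ccc(C(F)(F)F)nc1SCCOc1ccccc1)c1ccc(NS(C)(=O)=O)c(F)c1`, gives 118 nM
- compound 3, `CC(C(=O)NCc1ccc(C(F)(F)F)nc1SCCCN1CCCCC1)c1ccc(NS(C)(=O)=O)c(F)c1`, gives 250 nM

These three share one core and differ only in the group carried on the chain attached to the sulfur. In an assay on CHO-K1 cells for antagonist activity at transient receptor potential cation channel subfamily V member 1 (Homo sapiens), read by FLIPR (a higher number here means a weaker inhibitor, a lower number a stronger inhibitor), compound 1 shows the lowest of the three numbers, though compound 2 lies within the scatter of it; only compound 3 lies beyond. The steps are a 1.4-fold higher number from compound 1 to compound 2 (0.16 log units; within the scatter), a 3.0-fold higher number from compound 1 to compound 3 (0.48 log units; beyond the scatter) and a 2.1-fold higher number from compound 2 to compound 3 (0.33 log units; beyond the scatter).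

Compound 4, `CC(C(=O)NCc1ccc(C(F)(F)F)nc1SCc1ccc(Cl)cc1)c1ccc(NS(C)(=O)=O)c(F)c1`, is not yet measured. It differs from compound 1 as follows: 4-chlorophenyl in place of isobutyl on a saturated chain carbon bound to a sulfur. Both steps from compound 1 bear on this. Putting an aromatic ring on the chain gave a 1.4-fold higher number from compound 1 to compound 2 (0.16 log units; within the scatter), while the (piperidin-1-yl)methyl change gave a 3.0-fold higher number from compound 1 to compound 3 (0.48 log units; beyond the scatter). Because a 1.4-fold higher number from compound 1 to compound 2 (0.16 log units; within the scatter) stayed within the scatter, compound 4 is expected to land near compound 1, with an expected step of a 1.2-fold higher number from compound 1 to compound 4 (0.09 log units; within the scatter). Compound 4 is therefore estimated at 100 nM, between 40 nM and 250 nM.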

Compound 4, half-maximal inhibitory concentration: 674 nM
The estimate for compound 4 lay 6.7-fold (0.83 log units) below the measured number, and the stated range ends below it.
By their numbers in this assay, from the lowest: compounds 1 and 2 (each within the scatter of the next); then compound 3; then compound 4.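

In this assay, placing 4-chlorophenyl on the saturated chain carbon bound to a sulfur gives an 8.2-fold higher number from compound 1 to compound 4 (0.91 log units; beyond the scatter) and this is the largest step in the set. The phenoxymethyl group also carries an aromatic ring, yet replacing it with 4-chlorophenyl gives a 5.7-fold higher number from compound 2 to compound 4 (0.76 log units; beyond the scatter) and replacing 2-(piperidin-1-yl)ethyl gives a 2.7-fold higher number from compound 3 to compound 4 (0.43 log units; beyond the scatter) as well, so an aromatic ring on this chain does not by itself keep the number low. No measurement shown here accounts for this loss of potency.

Compound 4 differs from compound 2 both in the chlorine and in how the ring is joined to the chain, so these two changes cannot be separated. A plain phenyl in place of 4-chlorophenyl, or a longer chain carrying the same 4-chlorophenyl, would tell them apart.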